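Replacing a Chloro Group by Amino on the Shared Core

This account rests on a few compounds, and the source may have more. Where it says the series, first, only, none or still open, it means among the compounds named here.

Three measured compounds share a fused core carrying two chloro groups and a benzyl bearing a chloromethyl group. Compound 1 `ClCc1ccccc1Cn1cnc2c(Cl)nc(Cl)nc21` is tested in a functional assay on IGROV-1 cells (Homo sapiens) for cytotoxicity, read by sulforhodamine B assay, with a stated time of 48 h (on this read-out higher numbers stand for lower toxicity in this test and lower numbers for higher toxicity in this test), where compound 1 gives 7070 nM. Compound 2 `ClCc1ccc(Cn2cnc3c(Cl)nc(Cl)nc32)cc1` gives 60300 nM in this assay, and compound 3 `ClCc1cccc(Cn2cnc3nc(Cl)nc(Cl)c32)c1` gives 55000 nM. Among these three numbers compound 1 has the lowest, and both compound 2 and compound 3 sit beyond the usual scatter from it, so compound 1 is the most toxic of the three in this assay.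

Compound 4 `Nc1nc(Cl)c2ncn(Cc3ccccc3CCl)c2n1` differs from compound 1 in one place: amino in place of chloro on an aromatic carbon, on an aromatic carbon of a six-membered aromatic ring with two nitrogen atoms, between two ring nitrogen atoms. For the measured compounds named here, no measured pair shows this exchange, so its effect cannot be read from the data at hand. The chloromethyl group carried by all four compounds is kept unchanged. Compound 4 is expected to be somewhat less toxic than compound 1, with an estimated step of a 2.1-fold higher number from compound 1 to compound 4 (0.33 log units; beyond the scatter) of modest size that may reach just beyond the scatter. Compound 4 is estimated at 15000 nM, expected between 5000 nM and 45000 nM.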

Compound 4, concentration lethal to 50% of the cells: > 100000 nM
Compound 4: no number, only a limit; the forecaster's own chance of this, stated with the estimate: 10%; middle value at least 6.6-fold (0.82 log units) from the limit.
By their numbers in this assay, from the lowest: compound 1; then compounds 3 and 2 (each within the scatter of the next). At a limit, above all of these: compound 4.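

Compound 4 gives only a limit in this assay, > 100000 nM, and this is a limit of the assay and not a number. For the compounds shown here, all three earlier compounds keep chloro on the aromatic carbon between two ring nitrogen atoms, so they could say nothing about this position; amino in place of chloro there now gives an at least 14-fold higher number from compound 1 to compound 4 (1.15 log units; beyond the scatter), a large step towards lower toxicity in this test, and it shows that this one exchange on the shared core can outweigh the differences seen among the earlier compounds. The step marks only a minimum, and the true size of the change stays unknown, since the value behind it lies at the edge of the assay's range: the limit of > 100000 nM in this assay, at which 1 of the 4 values shown sits.

The compounds shown leave open whether a methylamino group, a methoxy group or a hydroxyl group on this carbon would stay close to chloro or move as far as amino. They also leave open whether the same exchange carries a similar step with the benzyl arrangement of compound 2 or the core of compound 3, and what amino would do in place of the remaining chloro group.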